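Cyano for methyl on a benzothiazole amide: no foothold yet

The compounds below may be only part of what the source reports. "The series", "measured", "known", "first", "only" and "open" are said of these compounds alone.

Compound 1 `COc1cccc2sc(NC(=O)c3ccc(C(F)(F)F)cc3)nc12` gives > 10 ug/mL in a functional assay on NUGC-3 cells (Homo sapiens) for antiproliferative activity, read by sulforhodamine B assay; on this read-out lower numbers stand for stronger inhibition of growth and higher numbers for weaker inhibition of growth. Compound 2 `COc1ccc2sc(NC(=O)c3ccc(C)cc3)nc2c1` gives > 10 ug/mL in this assay. Compound 3 `O=C(Nc1ccccc1)Nc1nc2ccc(F)cc2s1` gives > 10 ug/mL in this assay.

Each of these three values is a limit of the assay and not a number. Compound 2 therefore stands at the limit of > 10 ug/mL in this assay, at which 3 of the 3 values shown sit, and the two others sit there with it, so nothing separates any of the three. Among the measured compounds shown here, no pair of them differs in a single place, and no measured step exists from which a direction could be read.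

Compound 4 `COc1ccc2sc(NC(=O)c3ccc(C#N)cc3)nc2c1` arises from compound 2 through (cyano in place of methyl on an aromatic carbon), cyano in place of methyl on an aromatic carbon. With every value shown being a limit, there is no ground for expecting a step beyond the scatter in either direction in this assay. Compound 4 is accordingly expected to give about 10 ug/mL, most likely again only as a limit, with a range from 3 ug/mL to 30 ug/mL. The step of a number no higher from compound 2 to compound 4 (the limit leaves the size open) is thus estimated to be no larger than the scatter.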

Compound 4, concentration for 50% growth inhibition: > 10 ug/mL
Compound 4 gave a limit, no number (the forecaster's own chance of this, stated with the estimate: 75%); the middle value sits exactly at the limit.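

In this assay, among the compounds shown here, compound 4 gives > 10 ug/mL, a limit of the assay and not a number, so no step from compound 2 to compound 4 can be read. What cyano in place of methyl on an aromatic carbon does to growth inhibition stays open, as does any ranking of the compounds shown: the limit of > 10 ug/mL in this assay, at which 4 of the 4 values shown sit.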